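The source may hold more compounds than are shown below. What is called first, only, known or untested is meant among the compounds shown, and "the series" means these compounds.

Compound 1 `CC1=C(/C=C/C(=O)/C=C/c2ccc(C(F)(F)F)cc2)C(C)(C)CCC1O` and compound 2 `CC1=C(/C=C/C(=O)/C=C/c2ccccc2F)C(C)(C)CCC1O` share one core and differ only in the substitution of the aryl ring. In a functional assay on PC-3 cells (Homo sapiens) for cytotoxicity, read by MTT assay, with a stated time of 72 h (a higher number here means a weaker inhibitor, a lower number a stronger inhibitor), compound 1 gives 10200 nM, and compound 2 gives 10400 nM; compound 2 stands as the higher of the two numbers, yet its gap to compound 1 is within the scatter. Compound 3 `CC1=C(/C=C/C(=O)/C=C/c2ccc(C(F)(F)F)cc2F)C(C)(C)CCC1O` carries trifluoromethyl in place of hydrogen on an aromatic carbon. Within the data shown here, no measured step isolates this change, so the step from compound 2 to compound 3 is estimated at a 1.3-fold lower number from compound 2 to compound 3 (0.11 log units; within the scatter), not beyond the scatter. Compound 3 is therefore expected to give 8000 nM in this assay, between 3000 nM and 20000 nM.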

Compound 3, half-maximal inhibitory concentration: 4600 nM
Compound 3: the middle estimate sits 1.7-fold (0.24 log units) above what was measured, and the stated range covers the measured number.
By their numbers in this assay, from the lowest: compound 3; then compounds 1 and 2 (each within the scatter of the next).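

Trifluoromethyl on the aromatic carbon para to a large group, with the fluoro group already present, gives in this assay a 2.3-fold lower number from compound 2 to compound 3 (0.35 log units; beyond the scatter) and so a modest gain at this position. Fluoro in place of hydrogen on an aromatic carbon, with the trifluoromethyl already present, gives a 2.2-fold lower number from compound 1 to compound 3 (0.35 log units; beyond the scatter) of similar size. Only the compound carrying both groups separates from the other two, and nothing shown accounts for this.
Open, from the compounds shown here alone, is whether a nitrile or an amine at this position would give a step of similar size. Also open, going by these compounds, is what either group does on the shared core without the other.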